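The source may hold more compounds than are shown below. What is called first, only, known or untested is meant among the compounds shown, and "the series" means these compounds.

In a functional assay on HeLa cells (Homo sapiens) for antiproliferative activity, read by MTT assay, with a stated time of 72 h (on this read-out lower numbers stand for stronger inhibition and higher numbers for weaker inhibition), compound 1 `CC(=O)OCC(CCn1cc(C#Cc2cc(F)cc(F)c2)c(=O)n(C(=O)c2ccccc2)c1=O)COC(C)=O` gives 64500 nM and compound 2 `O=c1[nH]c(=O)n(CCC(CO)CO)cc1C#CCc1ccccc1` gives 63800 nM; the two numbers sit within the scatter of each other, so neither is set apart from the other on this assay. Compound 3 `O=c1[nH]c(=O)n(CCC(CO)CO)cc1C#CCCCCl` is compound 2 with 2-chloroethyl in place of phenyl on a saturated chain carbon bound to a triple-bonded carbon. Going by the values given here, no measured pair shows this change, so the step from compound 2 to compound 3 is expected to stay within the scatter, a 1.1-fold higher number from compound 2 to compound 3 (0.04 log units; within the scatter). For compound 3 the value in this assay is estimated at 70000 nM, within 25000 nM to 200000 nM.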

Compound 3, half-maximal inhibitory concentration: > 100000 nM
Compound 3 ended at the assay's limit; the forecaster's own chance of this, stated with the estimate: 30%; at least 1.4-fold (0.15 log units) between middle value and limit.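

In this assay compound 3 reads > 100000 nM as a limit of the assay and not a number. Going by these compounds alone, the only step at this saturated chain carbon is an at least 1.5-fold higher number from compound 2 to compound 3 (0.19 log units; that floor lies within the scatter) and so 2-chloroethyl in place of phenyl brings no lower number, while the true size of the change stays unread. The reading is bounded on one side only: the limit of > 100000 nM in this assay, at which 1 of the 3 values shown sits.

On these data alone, how far compound 3 lies past the limit remains open. Also open, as far as these compounds go, is whether an amine, a carboxylic acid or a longer chain at this place would give a lower number than compound 2.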